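The compounds below may be only part of what the source reports. "The series", "measured", "known", "first", "only" and "open" are said of these compounds alone.

In a physicochemical assay for lipophilicity, at pH 7.4 (on this read-out higher numbers stand for higher lipophilicity and lower numbers for lower lipophilicity), compound 3 `Cc1cc(C(=O)NCc2ccccn2)nn1Cc1cc(Cl)ccc1OCc1ccccc1` gives > 3.7, which is a limit and not a number. Compound 4 `Cc1cc(NC(=O)CC(C)(C)C)nn1Cc1cc(Cl)ccc1OCc1ccccc1` differs from it at one place on the shared core: (neopentylcarbonyl)amino in place of ((pyridin-2-yl)methyl)carbamoyl on an aromatic carbon. For the measured compounds named here, no measured step makes this exact exchange, so the nearest guides are changes to the group on the amide nitrogen. Compound 1 `Cc1cc(C(N)=O)nn1Cc1cc(Cl)ccc1OCc1ccccc1` gives 3.7, and compound 2 `Cc1cc(C(=O)Nc2cccc(F)c2)nn1Cc1cc(Cl)ccc1OCc1ccccc1` gives 2.8. That is a number 0.90 log units lower from compound 1 to compound 2 (beyond the scatter). The other two steps are a number at least 0.90 log units higher from compound 2 to compound 3 (beyond the scatter) and a number no lower from compound 1 to compound 3 (the limit leaves the size open). These steps run in both directions, so they fix no direction here, and only a loose, modest change can be expected. The expected step is a number at least 0.20 log units lower from compound 3 to compound 4 (that floor lies within the scatter). For compound 4 the estimated value is 3.5, within an expected range from 2.8 to 4.1.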

Compound 4, distribution coefficient: > 3.7
Compound 4 was reported as a limit; the forecaster's own chance of this, stated with the estimate: 35%; at least 0.20 log units between middle value and limit.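

In this assay compound 4 gives > 3.7, which is a limit and not a number. (neopentylcarbonyl)amino in place of (3-fluorophenyl)carbamoyl on an aromatic carbon gives a number at least 0.90 log units higher from compound 2 to compound 4 (beyond the scatter), so a group with no ring can reach this limit. (neopentylcarbonyl)amino in place of carbamoyl on an aromatic carbon gives a number no lower from compound 1 to compound 4 (the limit leaves the size open). The step to compound 4 from compound 3 cannot be read, because the limit hides its size: the limit of > 3.7 in this assay, at which 2 of the 4 values shown sit.

From the compounds shown here alone, how far compound 3 and compound 4 lie beyond that limit stays open. So does what an amine or a carboxylic acid on this aromatic carbon would give.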